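The source may hold more compounds than are shown below. What is called first, only, known or untested is meant among the compounds shown, and "the series" means these compounds.

In a functional assay for inhibition, with Homo sapiens as the target (a lower number here means a stronger inhibitor, a higher number a weaker inhibitor), compound 1 `CCOC(=O)c1ccc2oc(NC(CC3CCCCC3)c3ccccc3)nc2c1` gives 45 nM and compound 2 `O=C(O)c1ccc2oc(NC(CC3CCCCC3)c3ccccc3)nc2c1` gives 150 nM, the higher of the two numbers, which makes compound 2 the weaker inhibitor of this pair. Compound 3 `N#Cc1ccc2oc(NC(CC3CCCCC3)c3ccccc3)nc2c1` keeps the shared core but has cyano in place of carboxy on an aromatic carbon. Going by the values given here, only one measured step bears on this change. Swapping ethyl for hydrogen on the ester oxygen gave a 3.3-fold higher number from compound 1 to compound 2 (0.52 log units; beyond the scatter), a modest change that lies beyond the scatter. Compound 3, like compound 1 at 45 nM, has no free carboxy group, which suggests a partial return towards the lower number. One step is thin evidence, however, and a nitrile is not an ester. The expected step is modest and downward: a 2.1-fold lower number from compound 2 to compound 3 (0.33 log units; beyond the scatter). For compound 3 the estimate is 70 nM, with an expected range of 25 nM to 200 nM.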

Compound 3, half-maximal inhibitory concentration: 15 nM
Beside the measured number, compound 3's estimate is 4.7-fold (0.67 log units) above it; the measured number lies below the stated range.
By their numbers in this assay, from the lowest: compound 3; then compound 1; then compound 2.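

At this aromatic carbon, cyano in place of carboxy gives a 10-fold lower number from compound 2 to compound 3 (1.00 log units; beyond the scatter) in this assay. The nitrile does more than recover the ground lost by the free acid, since replacing the ester group gives a 3.0-fold lower number from compound 1 to compound 3 (0.48 log units; beyond the scatter), which leaves compound 3 the strongest inhibitor of the three. So, among these compounds, an ester is not the best group at this position, and a group with no hydrogen-bond donor can outperform both the ester and the acid, although nothing shown here explains why.

From the compounds shown here alone, whether other small groups, such as a primary amide, a trifluoromethyl group or a chlorine atom, would match the nitrile at this carbon remains open. So does whether the nitrile's advantage would persist if the cyclohexyl or phenyl group on the side chain were replaced.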